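The source may report more compounds than this note shows. Statements on the series, on what has been measured and on what is new or still open speak of the compounds shown alone.

Compound 1 `COCCC1=C(N2CC2)C(=O)C(C)=C(N2CC2)C1=O` gives 5.57 in a functional assay on L1210 cells (Mus musculus), with a stated time of 12 days (a lower number here means a less potent compound, a higher number a more potent compound, by a factor of ten per unit of this negative logarithm), which is the second highest of the three numbers measured. Compound 2 `COCCC1=C(N2CC2)C(=O)C(CCOC)=C(N2CC2)C1=O` gives 5.69, a step of a number 0.12 log units higher from compound 1 to compound 2 (within the scatter). Compound 3 `CC1=C(N2CC2)C(=O)C(CCCc2ccccc2)=C(N2CC2)C1=O` gives 4.47, a step of a number 1.10 log units lower from compound 1 to compound 3 (beyond the scatter). Compound 4 `CC1=C(N2CC2)C(=O)C(N2CC2)=C(N2CC2)C1=O` differs from compound 1 by aziridin-1-yl in place of 2-methoxyethyl on a double-bonded ring carbon. Neither measured step swaps a side chain for a ring, so neither bears directly on this change. The two measured side-chain changes moved the number little or downward, which gives only a loose guide. For compound 4 the change is expected to give a step of a number 0.43 log units higher from compound 1 to compound 4 (beyond the scatter), upward but with wide uncertainty. Compound 4 is therefore estimated at 6, with a range from 5.2 to 6.8.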

Compound 4, logarithm of the reciprocal of the active concentration, log(1/C): 6.77
Compound 4: middle estimate off by 0.77 log units, on the low side, within the range that was stated.
By their numbers in this assay, from the lowest: compound 3; then compounds 1 and 2 (each within the scatter of the next); then compound 4.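

Aziridin-1-yl in place of 2-methoxyethyl on this double-bonded ring carbon gives a number 1.20 log units higher from compound 1 to compound 4 (beyond the scatter) in this assay and is the first change shown to raise the number beyond the scatter. The earlier steps shown here only altered a saturated chain, whereas this one replaces the whole chain on the ring carbon with a three-membered ring. Nothing measured here gives a reason for the rise.

From the compounds shown here alone, whether the three-membered ring itself matters stays open. So does whether a dimethylamino or morpholine group on this ring carbon would give a similar number.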